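The compounds below may be only part of what the source reports. "The series", "measured", "known", "first", "only" and "open" are said of these compounds alone.

Measured so far:
compound 1 `Nc1ccc(C(=O)/C=C/c2ccc(Cl)cc2)cc1` — 41%
compound 2 `O=C(CBr)Nc1ccc(C(=O)/C=C/c2ccc(Cl)cc2)cc1` — 44%

Among the measured compounds shown here, in a functional assay on the whole organism (strain albino) for inhibition, with Rattus norvegicus as the target, read by paw edema, with stated times of 30 min and 1 h, at a dose of 100 mg/kg by the oral route (on this read-out higher numbers stand for more inhibition at the one dose given (going by the name of the read-out) and lower numbers for less inhibition), compound 2 and compound 1 sit within the scatter of each other, the only measured step being a number 3 percentage points higher from compound 1 to compound 2 (within the scatter). For the measured compounds named here, compound 2 therefore stands at a number no different, beyond the scatter, from the one other number.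

Compound 3 `O=C(CO[N+](=O)[O-])Nc1ccc(C(=O)/C=C/c2ccc(Cl)cc2)cc1` differs from compound 2 by nitrooxy in place of bromo on a saturated chain carbon bound to a carbonyl carbon. Going by the values given here, no measured step exchanges a group on a saturated chain carbon bound to a carbonyl carbon; the one step available, a number 3 percentage points higher from compound 1 to compound 2 (within the scatter), altered the substituent on the aromatic nitrogen and stayed within the scatter. Nothing in the measured data points in either direction for this change, so the step to compound 3 in this assay is expected to be no change at the digits printed from compound 2 to compound 3 (within the scatter), not beyond the scatter. Compound 3 is accordingly estimated at 44%, with a range of 30% to 58%.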

Compound 3, a percentage reported as inhibition, in the whole organism at one dose (the size of the read-out at that dose, not a potency): 42%
For compound 3 the middle estimate is 2 percentage points above the measured one; low and high end bracket the measured number.
By their numbers in this assay, from the lowest: compounds 1, 3 and 2 (each within the scatter of the next).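

In this assay, nitrooxy in place of bromo on a saturated chain carbon bound to a carbonyl carbon gives a number 2 percentage points lower from compound 2 to compound 3 (within the scatter), so this first exchange at that carbon does not separate the two groups. ((Nitrooxy)methyl)carbonyl in place of hydrogen on the aromatic nitrogen gives a number 1 percentage points higher from compound 1 to compound 3 (within the scatter), which joins a number 3 percentage points higher from compound 1 to compound 2 (within the scatter) in showing that neither of these two substituents on that nitrogen separates from the hydrogen at the one dose given. No measurement bearing on why these numbers stay together is available.

On these data alone, whether an amine or a carboxylic acid on the same carbon would move the number beyond the scatter remains open. So does whether a longer chain carrying the nitrooxy would do so, and a single dose gives no view of potency.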